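This account rests on a few compounds, and the source may have more. Where it says the series, first, only, none or still open, it means among the compounds named here.

Measured in a functional assay on MV4-11 cells (Homo sapiens) for antiproliferative activity, read by CellTiter-Glo, with a stated time of 72 h; on this read-out higher numbers stand for weaker inhibition of growth and lower numbers for stronger inhibition of growth:
- compound 1 `COCCN[C@H]1CC[C@H](Nc2cc(-c3csc(OCC4CCOCC4)n3)c(Cl)cn2)CC1`: 570 nM
- compound 2 `COCCN[C@H]1CC[C@H](Nc2cc(-c3csc(NCC4CC4)n3)c(Cl)cn2)CC1`: 740 nM
- compound 3 `COCCN[C@H]1CC[C@H](Nc2cc(-c3csc(NCC4CCC4)n3)c(Cl)cn2)CC1`: > 10000 nM, a limit

Compound 3 stands at the limit of > 10000 nM in this assay, at which 1 of the 3 values shown sits, and this is a limit only.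

Compound 4 `COCCN[C@H]1CC[C@H](Nc2cc(-c3csc(NCC4CCCC4)n3)c(Cl)cn2)CC1` follows from compound 3 by cyclopentyl in place of cyclobutyl on a saturated chain carbon bound to a nitrogen on an aromatic ring.

The closest measured step is an at least 13-fold higher number from compound 2 to compound 3 (1.13 log units; beyond the scatter), which is large. an at least 17-fold higher number from compound 1 to compound 3 (1.24 log units; beyond the scatter) is also large, while a 1.3-fold higher number from compound 1 to compound 2 (0.11 log units; within the scatter) is not. These steps give no ground to expect a recovery, so no step beyond the scatter is expected in this assay. The expected step is an at least 1.2-fold lower number from compound 3 to compound 4 (0.09 log units; that floor lies within the scatter). For compound 4 the estimate is 8000 nM, with an expected range of 1500 nM to 20000 nM.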

Compound 4, concentration for 50% growth inhibition: 2160 nM
Estimate against measurement, compound 4: 3.7-fold (0.57 log units) above; the range from low to high includes it.
By their numbers in this assay, from the lowest: compounds 1 and 2 (each within the scatter of the next); then compound 4. At a limit, above all of these: compound 3.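

In this assay, the sharp loss seen with cyclobutyl is not a general penalty for enlarging the ring on this saturated chain carbon: cyclopentyl gives an at least 4.6-fold lower number from compound 3 to compound 4 (0.66 log units; beyond the scatter). The recovery is only partial, with a 2.9-fold higher number from compound 2 to compound 4 (0.47 log units; beyond the scatter) and, against the (oxan-4-yl)methoxy group, a 3.8-fold higher number from compound 1 to compound 4 (0.58 log units; beyond the scatter). Across compounds 2, 3 and 4 the number does not rise steadily with ring size, and compound 3 is a limit only: the limit of > 10000 nM in this assay, at which 1 of the 4 values shown sits.

Going by these compounds, it remains open whether cyclohexyl at this place would continue the recovery or lose it again. Also open, on these data alone, is whether an oxan-4-yl ring on the amino linkage would match the oxygen-linked group.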